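Half-life notes: 2-ethylbenzyl to 2-methoxybenzyl

The compounds below may be only part of what the source reports. "The series", "measured", "known", "first", "only" and "open" are said of these compounds alone.

Measured in an ADME assay on microsomes from liver (Homo sapiens) for metabolic stability; on this read-out lower numbers stand for a shorter-lived compound and higher numbers for a longer-lived compound:
- compound 1 `CCS(=O)(=O)c1ccc(CNC(=O)c2ccc3c(c2)cc(Cc2ccccc2Br)n3C(C)C)cc1` (0.25 h)
- compound 2 `CCc1ccccc1Cc1cc2cc(C(=O)NCc3ccc(S(=O)(=O)CC)cc3)ccc2n1C(C)C` (0.217 h)

Compound 2 cannot be told apart from compound 1 on these two numbers. Among the measured compounds shown here, both sit at a short half-life, and the only measured step (a 1.2-fold lower number from compound 1 to compound 2 (0.06 log units; within the scatter)) stays within the scatter. That step replaced bromo with ethyl on the same aromatic carbon. Compound 3 `CCS(=O)(=O)c1ccc(CNC(=O)c2ccc3c(c2)cc(Cc2ccccc2OC)n3C(C)C)cc1` brings (methoxy in place of ethyl on an aromatic carbon), with methoxy in place of ethyl on an aromatic carbon. For the measured compounds named here, no measured compound carries methoxy, so a shift in this assay beyond the scatter is not expected. The expected step is small (a 1.1-fold higher number from compound 2 to compound 3 (0.04 log units; within the scatter)). Compound 3 is estimated at 0.24 h (expected range 0.13 h to 0.45 h).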

Compound 3, half-life: 0.217 h
Beside the measured number, compound 3's estimate is 1.1-fold (0.04 log units) above it; the measured number falls inside the stated range.
By their numbers in this assay, from the lowest: compounds 2, 3 and 1 (each within the scatter of the next).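

Methoxy now joins bromo and ethyl on this aromatic carbon, ortho to a large group, and in this assay both new steps stay within the scatter: no change at the digits printed from compound 2 to compound 3 (within the scatter) and a 1.2-fold lower number from compound 1 to compound 3 (0.06 log units; within the scatter). A group with a hydrogen-bond acceptor at this place therefore gives a half-life within the scatter of the two groups without one. No evidence bears on why these three compounds read alike.

As far as these compounds go, whether an amine or a carboxylic acid on this carbon would leave the scatter stays open. Also open, from the compounds shown here alone, is whether any change elsewhere on the shared core would lengthen the half-life.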